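The compounds below may be only part of what the source reports. "The series", "measured", "known", "first", "only" and "open" are said of these compounds alone.

Compound 1 `Cc1cc(=O)oc2cc(OCC(=O)c3ccc4c(c3)OCCCO4)ccc12`: > 100000 nM
Compound 2 `Cc1cc(=O)oc2cc(OCC(=O)c3ccc(OC(F)(F)F)cc3)ccc12`: > 100000 nM

In a functional assay on CWR22R cells (Homo sapiens) for antiproliferative activity, with a stated time of 96 h (on this read-out lower numbers stand for stronger inhibition and higher numbers for weaker inhibition), compound 1 gives > 100000 nM as a limit of the assay and not a number. Compound 2 gives > 100000 nM as a limit too. Compound 1 thus stands at the limit of > 100000 nM in this assay, at which 2 of the 2 values shown sit, and no exact number is known for it.

Compound 3 `O=C(COc1ccc2c(C(F)(F)F)cc(=O)oc2c1)c1ccc2c(c1)OCCCO2` has trifluoromethyl in place of methyl on an aromatic carbon, opposite the ring oxygen, a change from compound 1 counted as trifluoromethyl in place of methyl on an aromatic carbon here. Among the compounds with values here, no measured pair shows what such a change does. The estimated step in this assay is small, an at least 1.2-fold lower number from compound 1 to compound 3 (0.09 log units; that floor lies within the scatter) with a slight lean towards stronger inhibition, and the assay may again report only a limit. Compound 3 is estimated at 80000 nM with an expected range of 20000 nM to 100000 nM in this read-out.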

Compound 3, half-maximal inhibitory concentration: "not active" (no number reported)
For compound 3 the study gives words and no number; no gap can be computed for the estimate.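

No step can be read from compound 1 to compound 3: compound 3 is reported only in words as not active, and compound 1 has only a limit. The compounds shown leave open whether trifluoromethyl in place of methyl changes activity at all.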